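Acetylation of the side-chain hydroxyl in a lactone series

The source may hold more compounds than are shown below. What is called first, only, known or untested is meant among the compounds shown, and "the series" means these compounds.

compound 1, `CCCC[C@H](O)/C=C\[C@@H]1OC(=O)C=C[C@@H]1OC(C)=O`: 2 ug/mL
compound 2, `CCCC[C@@H](/C=C\[C@@H]1OC(=O)C[C@@H](OC)[C@@H]1O)OC(C)=O`: > 20 ug/mL
compound 3, `CCCC[C@H](OC(C)=O)[C@@H](O)[C@H](O)[C@@H]1OC(=O)C=C[C@@H]1OC(C)=O`: > 20 ug/mL

Among the measured compounds shown here, in a functional assay on KB-V1 cells (Homo sapiens) for cytotoxicity, read by sulforhodamine B assay, with a stated time of 72 h (on this read-out higher numbers stand for an effect only at larger amounts of compound and lower numbers for an effect already at smaller amounts), compound 1 gives 2 ug/mL, the only value that is a number in this set. For compound 2 only a limit is recorded, > 20 ug/mL. For compound 3 likewise only a limit is recorded, > 20 ug/mL. Both of these sit at the limit of > 20 ug/mL in this assay, at which 2 of the 3 values shown sit.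

Compound 4, `CCCC[C@@H](/C=C\[C@@H]1OC(=O)C=C[C@@H]1OC(C)=O)OC(C)=O`, differs from compound 1 by acetyl in place of hydrogen on an oxygen on a saturated carbon. For the measured compounds named here, no measured pair differs in this one place alone, so the step has no direct precedent. Compound 2 carries an acetoxy group on its side chain as well, but differs from compound 1 in further places, so its limit cannot be read as the effect of this change by itself. The expectation is a modest step, a 2.0-fold higher number from compound 1 to compound 4 (0.30 log units; within the scatter), toward an effect only at larger amounts. For compound 4 the estimate is 4 ug/mL, within 1.5 ug/mL to 15 ug/mL.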

Compound 4, concentration for half-maximal effect: 1.8 ug/mL
The estimate for compound 4 lay 2.2-fold (0.35 log units) above the measured number; the measured number falls inside the stated range.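

In this assay, acetyl in place of hydrogen on this side-chain oxygen gives a 1.1-fold lower number from compound 1 to compound 4 (0.05 log units; within the scatter). In this pair, a free hydroxyl at this position is therefore not required for the cytotoxic effect. Hydroxy to acetoxy does not by itself carry a compound to the limit reached elsewhere in the series: the limit of > 20 ug/mL in this assay, at which 2 of the 4 values shown sit.

Going by these compounds, what a benzoyl ester or an amine would do at this position remains open. The compounds shown also leave open which of the further differences in compound 2 and compound 3 goes with their limits.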